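The compounds below may be only part of what the source reports. "The series", "measured", "known", "first", "only" and "open" are said of these compounds alone.

Series on the shared core of compound 1 `CC(=O)NNC(=O)NCc1ccccc1`. In a functional assay on the whole organism with Mus musculus as the target, in the maximal electroshock model (on this read-out higher numbers stand for an effect only at larger amounts of compound and lower numbers for an effect already at smaller amounts), compound 1 reaches only a limit, > 100 mg/kg. Compound 2 `CC(=O)NN(C)C(=O)NCc1ccccc1` gives 89 mg/kg in this assay. Compound 3 `CC(=O)NN(C(=O)NCc1ccccc1)c1ccccc1` likewise returns only a limit in this assay, > 30 mg/kg. The step of an at least 1.1-fold lower number from compound 1 to compound 2 (0.05 log units; that floor lies within the scatter) lies within the scatter, while a step that the two limits leave unreadable from compound 1 to compound 3 and a step that the limit leaves unreadable from compound 2 to compound 3 stay unreadable because of the limit of > 100 mg/kg in this assay, at which 1 of the 3 values shown sits, and (the limit of > 30 mg/kg in this assay, at which 1 of the 3 values shown sits). Compound 4 `CC(=O)NN(C(=O)NCc1ccccc1)c1nccs1` differs from compound 3 by 1,3-thiazol-2-yl in place of phenyl on an amide-type nitrogen. Within the data shown here, no measured step touches this change, and the only anchor is the limit of compound 3, so no shift beyond the scatter is expected. The expected step is a step that the limit leaves unreadable from compound 3 to compound 4. Compound 4 is therefore estimated at about 60 mg/kg in this assay, with a range from 25 mg/kg to 150 mg/kg.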

Compound 4, dose for half-maximal effect: 22 mg/kg
For compound 4 the middle estimate is 2.7-fold (0.44 log units) above the measured one; the measured number lies below the stated range.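

In this assay, among these compounds, a substituent on this amide-type nitrogen gives, for the first time, a step that can be read beyond the scatter: 1,3-thiazol-2-yl in place of methyl produces (a 4.0-fold lower number from compound 2 to compound 4 (0.61 log units; beyond the scatter)). Compound 1 holds only a limit, so 1,3-thiazol-2-yl in place of hydrogen is a minimum (an at least 4.5-fold lower number from compound 1 to compound 4 (0.65 log units; beyond the scatter)). Compound 3 also holds only a limit, so an at least 1.3-fold lower number from compound 3 to compound 4 (0.13 log units; that floor lies within the scatter) gives no order between phenyl and 1,3-thiazol-2-yl.

As far as these compounds go, it remains open whether this step depends on the nitrogen and sulfur of 1,3-thiazol-2-yl. From the compounds shown here alone, it also remains open what pyridin-2-yl or a longer chain such as n-butyl would give on this nitrogen.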